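The source may hold more compounds than are shown below. What is called first, only, known or untested is meant among the compounds shown, and "the series" means these compounds.

Working notes on a series of piperazine amides examined in an assay on HEK293 cells for displacement of a labelled ligand from Melanocortin receptor 4 (Homo sapiens); a higher number here means a weaker inhibitor, a lower number a stronger inhibitor. Compound 1 `CCC(C)C(N)c1cc(C(F)(F)F)ccc1N1CCN(C(=O)CCc2ccc(Cl)cc2Cl)CC1` gives 160 nM in this assay. Compound 2 `NC(COCc1ccccc1)c1cc(F)ccc1N1CCN(C(=O)CCc2ccc(Cl)cc2Cl)CC1` gives 1000 nM in this assay. Compound 3 `CC(C)C[C@H](N)c1cc(C(F)(F)F)ccc1N1CCN(C(=O)CCc2cccc(C(F)(F)F)c2)CC1` gives 2200 nM in this assay, the highest of the three numbers: compound 2 sits nearest below it, by a gap beyond the scatter, and compound 1 sits furthest below it, by a gap also beyond the scatter. For the measured compounds named here, no two measured compounds differ in a single place, so no computed step is at hand within the measured set.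

Compound 4 `CC(C)C[C@H](N)c1cc(C(F)(F)F)ccc1N1CCN(C(=O)CCc2c[nH]c3ccccc23)CC1` has not yet been measured in this assay. It differs from compound 3 in one place: 1H-indol-3-yl in place of 3-(trifluoromethyl)phenyl on a saturated chain carbon, two bonds along the chain from a carbonyl carbon. The measured set holds no change of this kind, so the expectation rests on compound 3 alone as the reference point. The spread among compound 1, compound 2 and compound 3 shows how wide the numbers in this series run. The step from compound 3 to compound 4 is expected to be modest and toward a lower number, about a 1.8-fold lower number from compound 3 to compound 4 (0.26 log units; within the scatter), near the edge of the scatter rather than well beyond it. For compound 4 the estimate in this assay is 1200 nM, with a range from 300 nM to 5000 nM.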

Compound 4, inhibition constant: 640 nM
Beside the measured number, compound 4's estimate is 1.9-fold (0.27 log units) above it; the measured number falls inside the stated range.
By their numbers in this assay, from the lowest: compound 1; then compounds 4 and 2 (each within the scatter of the next); then compound 3.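

For the compounds shown here, the change from 3-(trifluoromethyl)phenyl to 1H-indol-3-yl on a saturated chain carbon, two bonds along the chain from a carbonyl carbon, gives a 3.4-fold lower number from compound 3 to compound 4 (0.54 log units; beyond the scatter) in this assay, a step beyond the scatter and the first reading of this position with the rest of the molecule held fixed. The number at this position therefore responds to the group it carries, and the lower value does not depend on keeping the trifluoromethyl group, as the entering group has no fluorine and brings a hydrogen-bond donor that the leaving group lacks. Nothing at hand accounts for the step, and this single change does not separate the contribution of the added five-membered aromatic ring from that of the hydrogen-bond donor or the loss of fluorine.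

Open, from the compounds shown here alone, is whether the hydrogen on the indole nitrogen matters, which a 1-methyl-1H-indol-3-yl or a benzofuran-3-yl group at the same position would test. Also open, going by these compounds, is whether the same exchange would give a step of similar size on the cores of compound 1 and compound 2.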